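Heteroaryl methylthio variants on a shared core: compound 4

The source may hold more compounds than are shown below. What is called first, only, known or untested is meant among the compounds shown, and "the series" means these compounds.

Measured so far in an assay on CHO cells for displacement of a labelled ligand from adenosine receptor A3 (Homo sapiens), read by scintillation counting, with a stated time of 120 min, tested at 1 uM; on this read-out higher numbers stand for more inhibition at the one concentration tested (going by the name of the read-out) and lower numbers for less inhibition:
compound 1 `N#Cc1c(N)nc(SCc2cccc(C(N)=O)c2)c(C#N)c1-c1ccc(OCC2CC2)cc1` gives 1%
compound 2 `N#Cc1c(N)nc(SCc2ncn[nH]2)c(C#N)c1-c1ccc(OCC2CC2)cc1` gives 1%
compound 3 `N#Cc1c(N)nc(SCc2ccn[nH]2)c(C#N)c1-c1ccc(OCC2CC2)cc1` gives 6%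

Compound 3 holds the highest of the three numbers, yet the gaps a number 5 percentage points higher from compound 1 to compound 3 (within the scatter) and a number 5 percentage points higher from compound 2 to compound 3 (within the scatter) lie within the scatter, so no ordering among the three is claimed. Compound 4 `N#Cc1c(N)nc(SCc2csc(N)n2)c(C#N)c1-c1ccc(OCC2CC2)cc1` differs from compound 3 by 2-amino-1,3-thiazol-4-yl in place of 1H-pyrazol-5-yl on a saturated chain carbon bound to a sulfur. For the measured compounds named here, the steps that bear on this change all swap the group on the saturated chain carbon bound to a sulfur: no change at the digits printed from compound 1 to compound 2 (within the scatter), a number 5 percentage points higher from compound 1 to compound 3 (within the scatter) and a number 5 percentage points higher from compound 2 to compound 3 (within the scatter), none beyond the scatter. Going by the values given here, no measured step introduces a 2-amino-1,3-thiazol-4-yl group. The expected step is therefore a number 1 percentage points lower from compound 3 to compound 4 (within the scatter), nothing beyond the scatter. Compound 4 is estimated to give 5% in this assay, expected between -5% and 15%.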

Compound 4, a percentage reported as inhibition, at one concentration (the size of the read-out at that concentration, not a potency): 1%
Compound 4: the middle estimate sits 4 percentage points above what was measured, and the stated range covers the measured number.
By their numbers in this assay, from the lowest: compounds 1, 2, 4 and 3 (each within the scatter of the next).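

In this assay, 2-amino-1,3-thiazol-4-yl on the saturated chain carbon bound to a sulfur gives a number 5 percentage points lower from compound 3 to compound 4 (within the scatter), no change at the digits printed from compound 2 to compound 4 (within the scatter) and no change at the digits printed from compound 1 to compound 4 (within the scatter). A thiazole carrying an amino group thus joins the pyrazole, triazole and carbamoylphenyl groups with no reading separable from theirs, so adding a ring sulfur and more hydrogen-bond acceptors at this position opens no gap among these four compounds. Nothing available explains this result.

On these data alone, whether a carboxylic acid, a simple alkyl amine or a longer chain at this position would give a number beyond the scatter remains open. So does whether replacing the cyclopropylmethoxy group would change these readings.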